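From 4-fluorophenyl to 2-methoxyphenyl on a shared core

A few compounds are considered here, and "the series" means these few. Any claim that something is new, unique, unknown or untested is made for them only; others in the source may bear on it.

- compound 1 `CCn1cc(-c2nnc(SCc3nnc(-c4ccc(F)cc4)o3)[nH]2)c(=O)c2cc(F)c(N3CCN(C)CC3)cc21` at 3800 nM
- compound 2 `CCn1cc(-c2nc(SCc3nnc(-c4ccc(F)cc4)o3)n(CN(C)C)n2)c(=O)c2cc(F)c(N3CCN(C)CC3)cc21` at 1500 nM

In a functional assay on CAPAN-1 cells (Homo sapiens) for antiproliferative activity (on this read-out higher numbers stand for weaker inhibition and lower numbers for stronger inhibition), compound 1 holds the higher of the two numbers, which makes it the weaker inhibitor of the pair, and its gap to compound 2 lies beyond the scatter. Compound 3 `CCn1cc(-c2nnc(SCc3nnc(-c4ccccc4OC)o3)[nH]2)c(=O)c2cc(F)c(N3CCN(C)CC3)cc21` keeps the core of compound 1 and carries 2-methoxyphenyl in place of 4-fluorophenyl on an aromatic carbon of the same five-membered ring. Among the measured compounds shown here, no measured pair shows this change, so no step beyond the scatter is expected. The expected step is a 1.3-fold lower number from compound 1 to compound 3 (0.10 log units; within the scatter) in this assay by this estimate. For compound 3 the estimated value is 3000 nM with an expected range of 1000 nM to 9000 nM when it is measured.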

Compound 3, half-maximal inhibitory concentration: 3800 nM
For compound 3 the middle estimate is 1.3-fold (0.10 log units) below the measured one; the range from low to high includes it.
By their numbers in this assay, from the lowest: compound 2; then compounds 1 and 3 (each within the scatter of the next).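

The exchange of 4-fluorophenyl for 2-methoxyphenyl gives no change at the digits printed from compound 1 to compound 3 (within the scatter) in this assay. Among the compounds shown here, this is the first reading at this position, and the oxygen-bearing group, with its hydrogen-bond acceptor, does not separate from the fluorine-bearing one. No measurement at hand explains why the two groups read alike.

From the compounds shown here alone, whether an amine or a carboxylic acid on the phenyl ring would move the number at this position remains open. So does whether the same exchange would read alike on the core of compound 2.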